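This account rests on a few compounds, and the source may have more. Where it says the series, first, only, none or still open, it means among the compounds named here.

Measured compounds in an ADME assay on microsomes from liver (Mus musculus) for metabolic stability, with a stated time of 30 min, tested at 1 uM; a higher number here means that more of the compound is left, a lower number that less of the compound is left:
compound 1 `CCN1CCN(c2ccc(Nc3ncc4c(n3)N(C)C(=O)N(c3cc(NC(=O)c5cccc(C(F)(F)F)c5)ccc3C)C4)cc2)CC1` gives 20.9%
compound 2 `Cc1ccc(NC(=O)c2cccc(C(F)(F)F)c2)cc1N1Cc2cnc(Nc3cnn(C)c3)nc2N(C)C1=O` gives 73.3%
compound 3 `CCN1CCN(c2ccc(Nc3ncc4c(n3)N(C)C(=O)N(c3cc(NC(=O)c5cccc(C(F)(F)F)c5)ccc3C)C4)cn2)CC1` gives 21.2%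

Compound 3 stands second highest of the three numbers. Its nearest neighbour is compound 1, whose value is lower by an amount within the scatter, so the two are not told apart. Compound 2 lies far above compound 3, beyond the scatter.

Compound 4 `CCN1CCN(C(=O)c2ccc(Nc3ncc4c(n3)N(C)C(=O)N(c3cc(NC(=O)c5cccc(C(F)(F)F)c5)ccc3C)C4)cn2)CC1` is the next step. It differs from compound 3 in one place: (4-ethylpiperazin-1-yl)carbonyl in place of 4-ethylpiperazin-1-yl on an aromatic carbon.

Going by the values given here, no measured pair covers this change, so nothing shows its direction. For compound 4 in this assay the expected step from compound 3 is a number 8.8 percentage points higher from compound 3 to compound 4 (within the scatter), small and not clearly beyond the scatter in either direction. Compound 4 is therefore estimated at 30%, with a range from 12% to 55%.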

Compound 4, percent of the compound remaining: 24.2%
Compound 4: the middle estimate sits 5.8 percentage points above what was measured; low and high end bracket the measured number.
By their numbers in this assay, from the lowest: compounds 1, 3 and 4 (each within the scatter of the next); then compound 2.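

In this assay the swap of 4-ethylpiperazin-1-yl for (4-ethylpiperazin-1-yl)carbonyl on this aromatic carbon next to the ring nitrogen gives a number 3 percentage points higher from compound 3 to compound 4 (within the scatter) and so does not separate the two compounds. At this position the added carbonyl therefore leaves the number unchanged within the scatter, and compound 4 stays in the low group. Nothing at hand speaks to the reason for this result.

Open, from the compounds shown here alone, is whether a morpholine or a carboxylic acid on this carbon would move the number beyond the scatter from compound 3.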